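The compounds below may be only part of what the source reports. "The series", "measured", "known", "first", "only" and "open" are said of these compounds alone.

Measured so far in a functional assay on THP-1 cells (Homo sapiens) for cytotoxicity, read by MTT assay, with a stated time of 24 h; on this read-out higher numbers stand for weaker inhibition and lower numbers for stronger inhibition:
compound 1 `COc1cc(/C=C2\CN(C)C/C(=C\c3ccc(F)cc3)C2=O)cc(OC)c1OC`, compound 1 gives 6130 nM
compound 2 `COc1cc(/C=C2\CN(C)C/C(=C\c3ccc(Cl)cc3)C2=O)cc(OC)c1OC`, compound 2 gives 7200 nM
compound 3 `CN1C/C(=C\c2ccc(F)cc2)C(=O)/C(=C/c2ccc(C#N)cc2)C1`, compound 3 gives 5030 nM

The three values lie within the scatter of one another. Compound 1 and compound 2 differ only by chloro in place of fluoro on an aromatic carbon, and the step of a 1.2-fold higher number from compound 1 to compound 2 (0.07 log units; within the scatter) is a flat result in this assay. Compound 4 `CN1C/C(=C\c2ccc(Cl)cc2)C(=O)/C(=C/c2ccc(C#N)cc2)C1` is not yet measured. It differs from compound 3 by chloro in place of fluoro on an aromatic carbon, the same change as before, with the place described in the same words. How the core of compound 3 differs from the core of compound 1 is not broken down here.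

The expected step is a 1.2-fold higher number from compound 3 to compound 4 (0.08 log units; within the scatter), resting on the flat result seen for the same change in a 1.2-fold higher number from compound 1 to compound 2 (0.07 log units; within the scatter). Compound 4 is estimated at 6000 nM in this assay, with a range from 3000 nM to 12000 nM.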

Compound 4, half-maximal inhibitory concentration: 3180 nM
Compound 4: the middle estimate sits 1.9-fold (0.28 log units) above what was measured, and the stated range covers the measured number.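

In this assay, the change from 4-fluorophenyl to 4-chlorophenyl gives a 1.6-fold lower number from compound 3 to compound 4 (0.20 log units; within the scatter), so the flat result holds on this second core. The two steps cannot be told apart: the same change on two cores in this assay, a 1.2-fold higher number (0.07 log units; within the scatter) from compound 1 to compound 2 and a 1.6-fold lower number (0.20 log units; within the scatter) from compound 3 to compound 4, 1.9-fold (0.27 log units) apart, within the scatter of two such steps. Across these four compounds, the change can therefore be carried from the core of compound 1 to the core of compound 3 without a detectable difference, but with one pair per core this does not show that it would stay flat on any other core, and the steps give no reliable direction.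

Still open, from the compounds shown here alone, is whether any group at this place moves the number beyond the scatter. An amine or a carboxylic acid in place of the chloro would test this on both cores.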